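The compounds below may be only part of what the source reports. "The series", "measured", "known", "first", "only" and "open" are said of these compounds alone.

Working notes on the series. The shared core is that of compound 1 `COc1cccc(Sc2sc(C(C)=O)nc2[N+](=O)[O-])c1`. For the measured compounds named here, in an assay on isolated protein for inhibition of ubiquitin carboxyl-terminal hydrolase 7 (Homo sapiens), read by fluorescence, with stated times of 30 min and 3 h (on this read-out higher numbers stand for weaker inhibition and lower numbers for stronger inhibition), compound 1 gives > 50000 nM, which is a limit of the assay and not a number; the only record for compound 1 is the limit of > 50000 nM in this assay, at which 1 of the 2 values shown sits. Compound 2 `O=C(NCc1cccc(F)c1)c1nc([N+](=O)[O-])c(Sc2c(Cl)cncc2Cl)s1` differs from compound 1 in several places at once; in this assay compound 2 gives 1350 nM. Compound 3 `COc1ccc(Sc2sc(C(C)=O)nc2[N+](=O)[O-])cc1OC` differs from compound 1 by methoxy in place of hydrogen on an aromatic carbon. Going by the values given here, no measured pair tracks this change. The step that the limit leaves unreadable from compound 1 to compound 3 is expected to be none beyond the scatter. For compound 3 in this assay the estimate is 70000 nM, expected between 20000 nM and 300000 nM.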

Compound 3, half-maximal inhibitory concentration: > 50000 nM
Compound 3: a limit, no number; the forecaster's own chance of this, stated with the estimate: 85%; the middle value lies beyond the limit too.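

Compound 1 and compound 3 both stand at a limit in this assay, so no step between them can be read: the limit of > 50000 nM in this assay, at which 2 of the 3 values shown sit.

On these data alone, whether methoxy in place of hydrogen on an aromatic carbon changes inhibition at all remains open.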